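Halogen on the aryl ring: the step to compound 4

The source may hold more compounds than are shown below. What is called first, only, known or untested is meant among the compounds shown, and "the series" means these compounds.

Measured so far:
compound 1 `CC1=NN(c2ccc(Br)cc2)C(=O)C12C=CC(=O)C=C2c1ccccc1`: > 100000 nM
compound 2 `CC1=NN(c2ccc(Cl)cc2)C(=O)C12C=CC(=O)C=C2c1ccc(C)cc1`: 14300 nM
compound 3 `CC1=NN(c2ccccc2)C(=O)C12C=CC(=O)C=C2c1ccc(C)cc1`: 91900 nM

In a functional assay on MDA-MB-231 cells (Homo sapiens) for antiproliferative activity, read by CCK-8 assay, with a stated time of 72 h (a lower number here means a stronger inhibitor, a higher number a weaker inhibitor), compound 3 stands at the weak end: its number is the highest of the two numbers shown, with compound 2 as its nearest neighbour. For compound 1 the value given is a limit of the assay and not a number, as noted in the limit of > 100000 nM in this assay, at which 1 of the 3 values shown sits.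

The unmeasured compound 4 `CC1=NN(c2ccc(Br)cc2)C(=O)C12C=CC(=O)C=C2c1ccc(C)cc1` differs from compound 3 in one place: bromo in place of hydrogen on an aromatic carbon. Among the compounds with values here, the only measured step that bears on this is the removal of a halogen from the same position, a 6.4-fold higher number from compound 2 to compound 3 (0.81 log units; beyond the scatter), a modest but clear rise in the number. Putting a halogen back is therefore expected to lower the number by a comparable amount. Compound 1 carries the same bromo group as compound 4 but differs on the other ring and sits at a limit, so it gives no usable number for the size of the step.

Compound 4 is therefore expected to land near 20000 nM, within 6000 nM to 80000 nM, which means an expected step of a 4.6-fold lower number from compound 3 to compound 4 (0.66 log units; beyond the scatter).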

Compound 4, half-maximal inhibitory concentration: 15900 nM
Compound 4: middle estimate off by 1.3-fold (0.10 log units), on the high side, within the range that was stated.
By their numbers in this assay, from the lowest: compounds 2 and 4 (each within the scatter of the next); then compound 3. At a limit, above all of these: compound 1.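

In this assay, the drop in the number on adding a halogen at the aromatic carbon para to a large group now holds for a second halogen: bromo in place of hydrogen gives a 5.8-fold lower number from compound 3 to compound 4 (0.76 log units; beyond the scatter), so the effect is not confined to chloro. Chloro and bromo at this position cannot be told apart, with a 1.1-fold higher number from compound 2 to compound 4 (0.05 log units; within the scatter), and the two compounds show no preference between these halogens. The methyl group on the other ring also matters with bromo held constant, giving an at least 6.2-fold lower number from compound 1 to compound 4 (0.79 log units; beyond the scatter), although compound 1 is a limit of the assay and not a number, so the size of this step has no upper bound: the limit of > 100000 nM in this assay, at which 1 of the 4 values shown sits.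

Going by these compounds, only hydrogen, chloro and bromo appear at this position, so it remains open whether fluoro, iodo, methoxy, trifluoromethyl or a carboxylic acid would follow the same trend. Also open, on these data alone, is how far the methyl step carries over to the chloro and hydrogen compounds, and whether an ethyl group, a methoxy group or an amine on the other ring would serve in place of methyl.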